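The source may report more compounds than this note shows. Statements on the series, on what has been measured and on what is new or still open speak of the compounds shown alone.

Compound 1, `O=C(Nc1cccc(-n2cc(-c3ccncc3)c(-c3cc(O)cc(Cl)c3)n2)c1)Nc1ccc(Cl)c(Cl)c1`, is the least altered member of this short series, and in a functional assay on SF-539 cells (Homo sapiens) for inhibition, read by sulforhodamine B assay, with a stated time of 48 h, tested at 10 uM (a lower number here means a stronger effect, a higher number a weaker effect of the compound at the concentration tested), compound 1 gives -29%. Compound 2, `COc1cc(Cl)cc(-c2nn(-c3cccc(NC(=O)Nc4ccc(Cl)c(C(F)(F)F)c4)c3)cc2-c2ccncc2)c1`, carries a trifluoromethyl where compound 1 has a chloro and a methyl on the oxygen, and in this assay compound 2 gives -1.17%. Compound 3, `COc1cc(Cl)cc(-c2nn(-c3cccc(NC(=O)Nc4ccc(Cl)c(Cl)c4)c3)cc2-c2ccncc2)c1`, sits at the top of the three numbers: in this assay compound 3 gives 21%. The step of a number 50 percentage points higher from compound 1 to compound 3 (beyond the scatter) is large, and the step of a number 22.2 percentage points higher from compound 2 to compound 3 (beyond the scatter) is modest. Compound 4, `COc1cc(Cl)cc(-c2nn(-c3cccc(NC(=O)c4cccc(C(F)(F)F)c4)c3)cc2-c2ccncc2)c1`, differs from compound 3 by 3-(trifluoromethyl)phenyl in place of (3,4-dichlorophenyl)amino on a carbonyl carbon. Neither measured step tests a change at the carbonyl carbon, so nothing shown speaks directly to it. The step from compound 2 to compound 3 does show that a ring bearing trifluoromethyl went with a lower number, and compound 4 again carries trifluoromethyl on that outer ring. Compound 4 is therefore expected to give a lower number than compound 3, with the step of a number 19 percentage points lower from compound 3 to compound 4 (beyond the scatter) estimated to be modest and the uncertainty wide. The estimate for compound 4 is 2%, within the range -30% to 30%.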

Compound 4, a percentage reported as activity, at one concentration (the size of the read-out at that concentration, not a potency): 64.2%
Compound 4: middle estimate off by 62.2 percentage points, on the low side; measured number above the stated range.
By their numbers in this assay, from the lowest: compound 1; then compound 2; then compound 3; then compound 4.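

In this assay, going by these compounds alone, the first change at the carbonyl carbon moves the read-out upward: 3-(trifluoromethyl)phenyl in place of (3,4-dichlorophenyl)amino gives a number 43.2 percentage points higher from compound 3 to compound 4 (beyond the scatter) and in place of (4-chloro-3-(trifluoromethyl)phenyl)amino gives a number 65.4 percentage points higher from compound 2 to compound 4 (beyond the scatter) on the same side. Both steps are large, whereas the chloro for trifluoromethyl swap on the outer ring was modest, so what sits on the carbonyl carbon matters more here than that swap, and compound 4 goes against the earlier link between trifluoromethyl and a lower number. Nothing shown explains this rise.

From the compounds shown here alone, the step removes the amino nitrogen and alters the ring substitution at once, so which of the two carries the rise stays open. Nor do the compounds shown say how a 3,4-dichlorophenyl or a piperidine on that carbonyl carbon would read.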